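Swapping 3-fluorophenyl for 2-hydroxyphenyl: an expected clearance

A few compounds are considered here, and "the series" means these few. Any claim that something is new, unique, unknown or untested is made for them only; others in the source may bear on it.

Compound 1 `Nc1ccc(S(=O)(=O)N2CCN(c3ncc(C(O)(C(F)(F)F)C(F)(F)F)cc3C#CC3CC3)CC2)cn1`: < 14 mL.min-1.g-1 (a limit of the assay)
Compound 2 `Nc1ccc(S(=O)(=O)N2CCN(c3ncc(C(O)(C(F)(F)F)C(F)(F)F)cc3-c3cccc(F)c3)CC2)cn1`: 25 mL.min-1.g-1

Among the compounds with values here, in an ADME assay (liver) for metabolic stability, with Liver microsome (Homo sapiens) as the target, using microsomes and NADPH, with a stated time of 30 min, tested at 1 uM (a higher number here means faster removal of the compound, a lower number slower removal), compound 2 gives 25 mL.min-1.g-1, the only true number so far. For compound 1 the result of < 14 mL.min-1.g-1 is a limit and not a number.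

Compound 3 `Nc1ccc(S(=O)(=O)N2CCN(c3ncc(C(O)(C(F)(F)F)C(F)(F)F)cc3-c3ccccc3O)CC2)cn1` carries 2-hydroxyphenyl in place of 3-fluorophenyl on an aromatic carbon, ortho to a large group. Within the data shown here, only one measured step changes the group at this place, an at least 1.7-fold higher number from compound 1 to compound 2 (0.25 log units; that floor lies within the scatter). That step brought in 3-fluorophenyl in place of 2-cyclopropylethynyl. Among the measured compounds shown here, no measured step involves 2-hydroxyphenyl, so the data give no direction, and the best starting point is compound 2 at 25 mL.min-1.g-1. The expected step, a 1.1-fold lower number from compound 2 to compound 3 (0.06 log units; within the scatter), stays within the scatter. Compound 3 is estimated at 22 mL.min-1.g-1, with an expected range of 11 mL.min-1.g-1 to 45 mL.min-1.g-1.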

Compound 3, intrinsic clearance in microsomes: 22 mL.min-1.g-1
Estimate against measurement, compound 3: no gap at the digits printed; low and high end bracket the measured number.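

In this assay, the new step is a 1.1-fold lower number from compound 2 to compound 3 (0.06 log units; within the scatter). At this place on the ring, then, 2-hydroxyphenyl, which brings a hydrogen-bond donor and a hydrogen-bond acceptor, cannot be told apart from 3-fluorophenyl, which has neither. Against 2-cyclopropylethynyl the step is an at least 1.5-fold higher number from compound 1 to compound 3 (0.19 log units; that floor lies within the scatter), and the result for compound 1 is a limit and not a number, so this step gives only a floor: the limit of < 14 mL.min-1.g-1 in this assay, at which 1 of the 3 values shown sits.

From the compounds shown here alone, the step from 3-fluorophenyl to 2-hydroxyphenyl changes both the atom on the phenyl ring and its place there, so the effect of each alone stays open; 2-fluorophenyl or 3-hydroxyphenyl would separate the two. Also open, going by these compounds, is whether an amine on the phenyl ring, as in 2-aminophenyl, would give a clearance like that of compound 3.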